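A few compounds are considered here, and "the series" means these few. Any claim that something is new, unique, unknown or untested is made for them only; others in the source may bear on it.

Working notes on the series.

Three members have numbers in a functional assay on the whole organism with Rattus norvegicus as the target, at a dose of 1 mg/kg by the oral route; a higher number here means a stronger effect of the compound at the dose given, a lower number a weaker effect. Compound 1, `Cc1cccc(-c2cc(C)cc(C(=O)Nc3nn[nH]n3)n2)c1`, gives 51%. Compound 2, `Cc1cc(C(=O)Nc2nn[nH]n2)nc(-c2ccc(N)cc2)c1`, gives 75% in this assay, and compound 3, `CCCCc1cc(C(=O)Nc2nn[nH]n2)nc(-c2cccc(C)c2)c1`, gives 36%, the lowest of the three. The step of a number 24 percentage points higher from compound 1 to compound 2 (beyond the scatter) accompanies the change (4-aminophenyl in place of 3-methylphenyl on an aromatic carbon). The step of a number 15 percentage points lower from compound 1 to compound 3 (beyond the scatter) accompanies the change in the core.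

Compound 4, `CCCCc1cc(C(=O)Nc2nn[nH]n2)nc(-c2ccc(N)cc2)c1`, awaits measurement. It differs from compound 3 by 4-aminophenyl in place of 3-methylphenyl on an aromatic carbon. Within the data shown here, this is the same kind of change as the one from compound 1 to compound 2, not the same: in compound 1 the place is meta to a group of 8 heavy atoms and meta to a methyl group, in compound 3 it is meta to a (2H-tetrazol-5-yl)carbamoyl group and meta to a butyl group. The two cores differ by propyl in place of hydrogen on a saturated chain carbon bound to an aromatic carbon.

Among the measured compounds shown here, only one earlier instance of this change exists, the step of a number 24 percentage points higher from compound 1 to compound 2 (beyond the scatter), and the expectation rests on it alone. The expected step is a number 22 percentage points higher from compound 3 to compound 4 (beyond the scatter), allowing for the possibility that the change reads differently on the butyl core. Compound 4 is thus estimated at 58% in this assay, with a range from 42% to 74%.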

Compound 4, a percentage reported as inhibition, in the whole organism at one dose (the size of the read-out at that dose, not a potency): 81%
The estimate for compound 4 lay 23 percentage points below the measured number, and the stated range ends below it.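

On the butyl core, 4-aminophenyl in place of 3-methylphenyl gives a number 45 percentage points higher from compound 3 to compound 4 (beyond the scatter) in this assay, so the change keeps its direction across the two cores but not its size: the same change on two cores in this assay, a number 24 percentage points higher (beyond the scatter) from compound 1 to compound 2 and a number 45 percentage points higher (beyond the scatter) from compound 3 to compound 4, 21 percentage points apart, beyond the scatter of two such steps. Seen from the other side, propyl in place of hydrogen on the chain gives a number 6 percentage points higher from compound 2 to compound 4 (within the scatter), so the outcome of the longer chain also depends on the aryl group present: the same change on two cores in this assay, a number 15 percentage points lower (beyond the scatter) from compound 1 to compound 3 and a number 6 percentage points higher (within the scatter) from compound 2 to compound 4, 21 percentage points apart, beyond the scatter of two such steps. This is a single pair of cores at one oral dose, which shows that the two changes do not add up in this series but does not show why, nor how the step would read on any other core.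

As far as these compounds go, whether the larger step holds with an ethyl or a hexyl chain in place of butyl remains open. Also open, from the compounds shown here alone, is whether the amine itself carries the step, or whether a hydroxyl group or a carboxylic acid in its place would read the same way on either core.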